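Aza-Substitution of the Chlorophenyl Arm in Compound 1

This account rests on a few compounds, and the source may have more. Where it says the series, first, only, none or still open, it means among the compounds named here.

Measured compounds: compound 1 `Clc1ccccc1-c1cc(-c2cnn(C3CCNCC3)c2)on1` gives 120 nM in an assay on isolated protein for positive allosteric modulation of Neuronal acetylcholine receptor; alpha4/beta2 (Homo sapiens); a higher number here means that more compound is needed for the effect, a lower number that less compound is needed; compound 2 `Fc1cccc(-c2cc(-c3cnn(C4CCNCC4)c3)on2)c1Cl` gives 230 nM in this assay.

Among the measured compounds shown here, only two numbers are known. For the measured compounds named here, compound 1 sits at one end of them, and its only neighbour is compound 2, reached by the step of a 1.9-fold higher number from compound 1 to compound 2 (0.28 log units; within the scatter), so the two compounds cannot be told apart on this assay.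

Compound 3 `Clc1cnccc1-c1cc(-c2cnn(C3CCNCC3)c2)on1` differs from compound 1 in one place: 3-chloropyridin-4-yl in place of 2-chlorophenyl on an aromatic carbon. Going by the values given here, none of the measured steps bears on this change. The step from compound 1 to compound 2 concerns a fluoro in place of hydrogen on the same aromatic ring, not the exchange of that ring for a 3-chloropyridin-4-yl, and it was within the scatter anyway. The expectation for compound 3 therefore rests on the structural change alone and is uncertain. A step in this assay of roughly a 2.1-fold higher number from compound 1 to compound 3 (0.32 log units; beyond the scatter) is expected, towards a higher number, but a result within the scatter cannot be excluded. Compound 3 is estimated at 250 nM, within a range of 90 nM to 700 nM.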

Compound 3, half-maximal effective concentration: 200 nM
The estimate for compound 3 lay 1.3-fold (0.10 log units) above the measured number; the range from low to high includes it.
By their numbers in this assay, from the lowest: compounds 1, 3 and 2 (each within the scatter of the next).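

In this assay, putting 3-chloropyridin-4-yl in place of 2-chlorophenyl on this aromatic carbon of the five-membered ring gives a 1.7-fold higher number from compound 1 to compound 3 (0.22 log units; within the scatter), so this position tolerates the exchange of a carbon-only ring for one with a ring nitrogen and a hydrogen-bond acceptor, with no difference that the assay can resolve. The comparison with the fluorinated arm reads the same way, with a 1.2-fold lower number from compound 2 to compound 3 (0.06 log units; within the scatter), so the 2-chlorophenyl, 2-chloro-3-fluorophenyl and 3-chloropyridin-4-yl arms cannot be told apart here, and this position has so far shown no step beyond the scatter. No measurement is available that bears on why the ring nitrogen leaves the number within the scatter.

It remains open whether this tolerance depends on the chlorine, since the compounds shown do not say how a pyridin-4-yl arm without it, or one carrying methyl or methoxy instead, would behave. They also leave open whether a pyridine with its nitrogen elsewhere in the ring, or a pyrimidine with a second ring nitrogen, would stay within the scatter of compound 1.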